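Swapping the amide cap of a potent aminoquinoline-type antiproliferative

The compounds below may be only part of what the source reports. "The series", "measured", "known", "first", "only" and "open" are said of these compounds alone.

Two compounds share a core and differ only in the group attached to the amide carbonyl. Compound 1 `Nc1cccc2c(-c3cccc(NC(=O)c4ccc(Cl)c(C(F)(F)F)c4)c3)ccnc12` and compound 2 `Nc1cccc2c(-c3cccc(NC(=O)c4ccc5c(c4)OCCO5)c3)ccnc12` were both tested in a functional assay on SK-MEL-5 cells (Homo sapiens) for antiproliferative activity, read by sulforhodamine B assay, with a stated time of 48 h; a lower number here means a stronger inhibitor, a higher number a weaker inhibitor; compound 1 gives 1600 nM while compound 2 gives 45 nM, the lowest of the two numbers, and the gap between them lies well beyond the usual scatter. Compound 3 `Nc1cccc2c(-c3cccc(NC(=O)c4nccs4)c3)ccnc12` has not yet been measured. It differs from compound 2 by 1,3-thiazol-2-yl in place of 2,3-dihydro-1,4-benzodioxin-6-yl on a carbonyl carbon. For the measured compounds named here, with no measured pair of this kind to lean on, the change is expected to cost some activity, since the one measured swap of this cap, from compound 1 to compound 2, moved the number a great deal. The step from compound 2 to compound 3 is estimated to be a weakening a 6.7-fold higher number from compound 2 to compound 3 (0.82 log units; beyond the scatter). Compound 3 is expected to give about 300 nM in this assay, within a range from 60 nM to 1500 nM.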

Compound 3, half-maximal inhibitory concentration: 4100 nM
Beside the measured number, compound 3's estimate is 14-fold (1.14 log units) below it, and the stated range ends below it.
By their numbers in this assay, from the lowest: compound 2; then compound 1; then compound 3.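

In this assay, replacing the 2,3-dihydro-1,4-benzodioxin-6-yl group on the carbonyl carbon with 1,3-thiazol-2-yl gives a 91-fold higher number from compound 2 to compound 3 (1.96 log units; beyond the scatter), and compound 3 also ranks behind compound 1 , which gives 1600 nM. The position therefore responds strongly to the change of cap, and a small five-membered aromatic ring does not stand in for the larger fused group, even though the two groups have the same count of hydrogen-bond acceptors and no donors. Nothing here measures why the number moves so far.

On these data alone, it remains open whether the benzodioxin's carbon-only aromatic ring alone would keep the low number, which a plain phenyl group at this position could test. A methoxyphenyl group could likewise test whether the non-aromatic oxygen-containing ring needs to stay closed.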